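Replacing the Amino Group of Compound 1 with Methylseleno

A few compounds are considered here, and "the series" means these few. Any claim that something is new, unique, unknown or untested is made for them only; others in the source may bear on it.

Measured compounds:
Compound 1, `C[Se]c1nc(N)c2ccccc2n1`, gives > 100000 nM in a functional assay on CCRF-CEM cells (Homo sapiens) for cytotoxicity, read by MTT assay, with a stated time of 72 h (on this read-out lower numbers stand for higher toxicity in this test and higher numbers for lower toxicity in this test), which is a limit of the test.
Compound 2, `COc1ccc(CNc2nc(SC)nc3ncccc23)cc1`, gives > 100000 nM in this assay, also a limit.
Compound 3, `Nc1nc([SeH])nc2ccccc12`, gives 79100 nM in this assay.

Compound 1 thus stands at the limit of > 100000 nM in this assay, at which 2 of the 3 values shown sit, so only a limit and no number is known for it. Compound 4, `C[Se]c1nc([Se]C)c2ccccc2n1`, differs from compound 1 by a group of 2 heavy atoms (1 carbon, 1 selenium; no ring) in place of one nitrogen atom, on an aromatic carbon. Among the measured compounds shown here, no measured step exchanges this group. The only single-point step shown, an at least 1.2-fold lower number from compound 1 to compound 3 (0.10 log units; that floor lies within the scatter), alters the selenium substituent instead, and its floor lies within the scatter. Nothing shown therefore supports a step beyond the scatter in this assay. Compound 4 is expected to give 150000 nM, most likely between 50000 nM and 500000 nM. The expected step is a step that the limit leaves unreadable from compound 1 to compound 4.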

Compound 4, concentration lethal to 50% of the cells: 78500 nM
Beside the measured number, compound 4's estimate is 1.9-fold (0.28 log units) above it, within the range that was stated.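

This is the first change shown at this position, where methylseleno takes the place of the amino group, and in this assay it brings an at least 1.2-fold lower number from compound 1 to compound 4 (0.10 log units; that floor lies within the scatter). Compound 4 gives a readable number, but this floor alone establishes no real change. The true size of the step stays unknown because compound 1 sits at a limit of the test: the limit of > 100000 nM in this assay, at which 2 of the 4 values shown sit.

On these data alone, what a methylamino group, a chlorine atom or a longer chain such as ethylseleno would give at this position stays open.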